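Amide Variation and Mouse Microsomal Clearance in a Benzoxazole Series

The compounds below may be only part of what the source reports. "The series", "measured", "known", "first", "only" and "open" are said of these compounds alone.

Measured compounds:
- compound 1 `O=C(CCSc1nc2cc(Cl)ccc2o1)NC1CCCC1`: "not determined" (no result reported)
- compound 2 `O=C(CCSc1nc2cc(Cl)ccc2o1)N1CCC1`: 17.9 mL/min/g
- compound 3 `CC1CCN(C(=O)CCSc2nc3cc(Cl)ccc3o2)C1`: 90.7 mL/min/g

Within the data shown here, in an ADME assay on microsomes from liver (Mus musculus) for metabolic stability, read by LC-MS, using NADPH, with a stated time of 45 min, tested at 0.5 uM (on this read-out lower numbers stand for slow clearance and higher numbers for fast clearance), compound 1 gives "not determined" (no result reported), so only two numbers are available. In this assay compound 2 gives 17.9 mL/min/g, while compound 3 gives 90.7 mL/min/g, the higher of the two numbers; the step of a 5.1-fold higher number from compound 2 to compound 3 (0.70 log units; beyond the scatter) lies beyond the scatter.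

Compound 4 `CN(C)C(=O)CCSc1nc2cc(Cl)ccc2o1` is not yet measured. It differs from compound 3 by dimethylamino in place of 3-methylpyrrolidin-1-yl on a carbonyl carbon. Among the measured compounds shown here, the one measured step that bears on this change is a 5.1-fold higher number from compound 2 to compound 3 (0.70 log units; beyond the scatter), in which the larger amide substituent carried the higher number; the change to compound 4 goes toward a smaller substituent on the same carbonyl carbon. A step downward in this assay is therefore expected, of a size comparable to that measured step, and compound 4 is expected to give 25 mL/min/g, estimated between 10 mL/min/g and 60 mL/min/g, which is a 3.6-fold lower number from compound 3 to compound 4 (0.56 log units; beyond the scatter).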

Compound 4, intrinsic clearance in a liver preparation (reported as CLH), per the amount of preparation that the assay uses: 41.8 mL/min/g
The estimate for compound 4 lay 1.7-fold (0.22 log units) below the measured number, and the stated range covers the measured number.
By their numbers in this assay, from the lowest: compound 2; then compound 4; then compound 3.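

In this assay, the change to dimethylamino on the carbonyl carbon gives a 2.2-fold lower number from compound 3 to compound 4 (0.34 log units; beyond the scatter), yet the number remains above that of the azetidine amide, with a 2.3-fold higher number from compound 2 to compound 4 (0.37 log units; beyond the scatter). The open-chain amide therefore falls between the two ring amides, so the presence of a ring at this position does not by itself set the order: compound 2 and compound 3 both carry one and lie on opposite sides of compound 4. Nothing available here accounts for this order.

The compounds shown leave open where a pyrrolidin-1-yl without the methyl or a morpholin-4-yl would fall, which would help separate the effect of ring size from that of the methyl. With compound 1 giving "not determined" (no result reported), they also leave open how an amide that keeps its hydrogen compares.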